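Tert-Butyl on the Benzyl Ring of a Triazole Amide

A few compounds are considered here, and "the series" means these few. Any claim that something is new, unique, unknown or untested is made for them only; others in the source may bear on it.

Compound 1 `Cc1ccccc1-n1cc(CNC(=O)c2cccc3c2cnn3C(C)C)nn1`: 19200 nM
Compound 2 `CC(C)n1ncc2c(C(=O)NCc3cn(Cc4ccccc4)nn3)cccc21`: 4420 nM

In a functional assay on PC-3 cells (Homo sapiens) for inhibition, read by MTT assay, with a stated time of 72 h (on this read-out lower numbers stand for stronger inhibition and higher numbers for weaker inhibition), compound 2 gives the lower of the two numbers, and the step of a 4.3-fold lower number from compound 1 to compound 2 (0.64 log units; beyond the scatter) lies beyond the scatter. Compound 3 `CC(C)n1ncc2c(C(=O)NCc3cn(Cc4ccc(C(C)(C)C)cc4)nn3)cccc21` differs from compound 2 by tert-butyl in place of hydrogen on an aromatic carbon. Among the compounds with values here, no measured step bears on substitution at this place; the only known step concerns the group on the aromatic nitrogen. The step of a 1.3-fold lower number from compound 2 to compound 3 (0.10 log units; within the scatter) is therefore expected to stay within the scatter. Compound 3 is estimated at 3500 nM, between 1200 nM and 12000 nM.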

Compound 3, half-maximal inhibitory concentration: 8890 nM
Compound 3: middle estimate off by 2.5-fold (0.40 log units), on the low side; the measured number falls inside the stated range.
By their numbers in this assay, from the lowest: compounds 2 and 3 (each within the scatter of the next); then compound 1.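

In this assay tert-butyl in place of hydrogen on this aromatic carbon gives a 2.0-fold higher number from compound 2 to compound 3 (0.30 log units; within the scatter) and so does not separate the two compounds. Within the data shown here, this is the first measured change on the ring itself, since the earlier step concerned only the group on the aromatic nitrogen. Nothing available explains this result. On these data alone, whether an amine or a carboxylic acid on this same carbon would also stay within the scatter remains open, and so does the outcome with a group as small as methyl.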